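The compounds below may be only part of what the source reports. "The series", "measured", "known", "first", "only" and "open" are said of these compounds alone.

Of the compounds shown here, three have been measured in a functional assay on A-431 cells (Homo sapiens) for antiproliferative activity, read by MTT assay, with a stated time of 72 h; on this read-out higher numbers stand for weaker inhibition and lower numbers for stronger inhibition. Compound 1 `COc1cc2ncnc(Nc3cccc(F)c3)c2cc1OCCCCC(=O)Nc1ccc(S(N)(=O)=O)cc1` gives 29900 nM in this assay. Compound 2 `COc1cc2ncnc(Nc3cccc(C)c3)c2cc1OCCCCC(=O)Nc1ccc(S(N)(=O)=O)cc1` carries a methyl where compound 1 carries a fluoro. In this assay compound 2 gives 7460 nM, and that single exchange amounts to a 4.0-fold lower number from compound 1 to compound 2 (0.60 log units; beyond the scatter). Compound 3 `NS(=O)(=O)c1ccc(NC(=S)Nc2ccc3ncnc(Nc4ccc(C(F)(F)F)cc4)c3c2)cc1`, built on a thiourea linker rather than the amide chain of the other two, gives 18000 nM; it stands second highest of the three numbers, nearest to compound 1 and separated by a gap within the scatter, while against compound 2 its number is higher by a gap beyond the scatter.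

Compound 4 `CCc1ccc(Nc2ncnc3ccc(NC(=S)Nc4ccc(S(N)(=O)=O)cc4)cc23)cc1` differs from compound 3 in one place: ethyl in place of trifluoromethyl on an aromatic carbon. Going by the values given here, no measured step covers exactly this exchange on this core. Among the compounds with values here, the only related evidence is the step from compound 1 to compound 2, in which a small alkyl replacing a halogen on the same aromatic position lowered the number by a modest amount, and that step sits on a different linker. On that analogy a modest lowering of the number, within or slightly beyond the scatter, is the expectation for compound 4, amounting to a 2.0-fold lower number from compound 3 to compound 4 (0.30 log units; within the scatter). Compound 4 is therefore estimated to give about 9000 nM in this assay, with a likely range from 3000 nM to 30000 nM.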

Compound 4, half-maximal inhibitory concentration: 38400 nM
Compound 4: the middle estimate sits 4.3-fold (0.63 log units) below what was measured, and the stated range ends below it.
By their numbers in this assay, from the lowest: compound 2; then compounds 3, 1 and 4 (each within the scatter of the next, the first and the last beyond it).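

On the thiourea linker, ethyl in place of trifluoromethyl on this aromatic carbon, para to a large group, gives a 2.1-fold higher number from compound 3 to compound 4 (0.33 log units; beyond the scatter) in this assay and so raises the number, if modestly. The earlier exchange of a fluoro for a methyl on the amide chain ran the other way, with a 4.0-fold lower number from compound 1 to compound 2 (0.60 log units; beyond the scatter), so a small alkyl group in place of a fluorinated one does not lower the number across these compounds, and the step from compound 3 to compound 4 goes against any such rule. The two exchanges differ in the groups that leave and enter as well as in the linker, and nothing available explains why their directions differ.

From the compounds shown here alone, only these two groups are compared on the thiourea linker, so it remains open how a hydrogen, a chloro, a methoxy, an amine or a longer chain such as propyl would read at this carbon. Going by these compounds alone, it is also open whether trifluoromethyl and ethyl would keep the same order if carried on the amide chain of compound 1, since that chain and the thiourea linker share no matched pair here.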